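A Methyl Joins the Fluoropyridine Ether

The compounds below may be only part of what the source reports. "The series", "measured", "known", "first", "only" and "open" are said of these compounds alone.

Three acids sharing one core have been measured in a physicochemical assay for lipophilicity, read by LC-MS, in phosphate buffer, measured as octanol-water partition, with a stated time of 30 min, at pH 7.4, tested at 200 mM; on this read-out higher numbers stand for higher lipophilicity and lower numbers for lower lipophilicity. Compound 1 `Cn1c(COc2cccc(C(=O)O)c2)nc2ccc(Oc3ccc(Cl)cn3)cc21` gives 1.2. Compound 2 `Cn1c(COc2cccc(C(=O)O)c2)nc2ccc(Oc3ccc(F)cn3)cc21` gives 0.6, and compound 3 `Cn1c(COc2cccc(C(=O)O)c2)nc2ccc(Oc3ncccc3F)cc21` gives 0.6. Compound 3 thus stands level with compound 2, and the two together sit at the low end of the three numbers, with compound 1 the furthest away; the step of a number 0.60 log units lower from compound 1 to compound 3 (beyond the scatter) is beyond the scatter, while no change at the digits printed from compound 2 to compound 3 (within the scatter).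

Compound 4 `Cc1cc(F)cnc1Oc1ccc2nc(COc3cccc(C(=O)O)c3)n(C)c2c1` differs from compound 3 by 5-fluoro-3-methylpyridin-2-yl in place of 3-fluoropyridin-2-yl on an oxygen on an aromatic ring. Two of the measured steps bear on it. The step of no change at the digits printed from compound 2 to compound 3 (within the scatter) shows that moving the fluorine on the pyridine between these two positions made no difference, so the fluorine part of the change is expected to be neutral. Going by the values given here, no measured step shows the effect of a methyl on the pyridine, but a methyl is usually a modest upward move in this assay. The step of a number 0.50 log units higher from compound 3 to compound 4 (beyond the scatter) is therefore expected to be upward and modest. Compound 4 is estimated at 1.1, with a range from 0.7 to 1.5.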

Compound 4, distribution coefficient: 1.1
For compound 4 middle estimate and measured number coincide at the digits printed; low and high end bracket the measured number.
By their numbers in this assay, from the lowest: compounds 2 and 3 (each within the scatter of the next); then compounds 4 and 1 (each within the scatter of the next).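

In this assay, methyl in place of hydrogen on an aromatic carbon of the fluoropyridine gives a number 0.50 log units higher from compound 2 to compound 4 (beyond the scatter), the first measured read on a methyl at this position. The change from 3-fluoropyridin-2-yl to 5-fluoro-3-methylpyridin-2-yl gives a number 0.50 log units higher from compound 3 to compound 4 (beyond the scatter), while 5-fluoro-3-methylpyridin-2-yl in place of 5-chloropyridin-2-yl gives a number 0.10 log units lower from compound 1 to compound 4 (within the scatter), so on this read-out the methylated fluoropyridine ether cannot be told apart from the chloropyridine ether. Nothing measured here accounts for the size of the methyl step.

On these data alone, whether an ethyl or a methoxy group on the same aromatic carbon would give a similar step remains open. So does whether a methyl added to the 5-chloropyridin-2-yl group of compound 1 would shift the number as it does on the fluoropyridine.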